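Replacing an aryl linker by a flexible chain in compound 2

A few compounds are considered here, and "the series" means these few. Any claim that something is new, unique, unknown or untested is made for them only; others in the source may bear on it.

Compound 2 `NCc1ccc(-n2cc(-c3ccc4cc[nH]c4c3)c(C(F)(F)F)n2)cc1` gives 30 nM in an assay on isolated protein for inhibition of Myeloperoxidase (Homo sapiens) (on this read-out lower numbers stand for stronger inhibition and higher numbers for weaker inhibition), the lowest of the three numbers recorded. Compound 1 `CN(C)Cc1ccc(-n2cc(-c3ccc4cc[nH]c4c3)c3c(Cl)ccnc32)cc1` gives 120 nM in this assay, and compound 3 `FC(F)(F)c1nn(-c2ccc(Cc3nc[nH]n3)cc2)cc1-c1ccc2cc[nH]c2c1` gives 250 nM; both lie beyond the scatter above compound 2.

Compound 4 `NCCCCn1cc(-c2ccc3cc[nH]c3c2)c(C(F)(F)F)n1` has not been measured. It differs from compound 2 in one place: 4-aminobutyl in place of 4-(aminomethyl)phenyl on an aromatic nitrogen. The primary amine is kept, but the six-membered aromatic ring that carried it in compound 2 is gone, and a chain of four carbons now links the amine to the five-membered aromatic ring.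

For the measured compounds named here, no measured step exchanges this linker, so none bears on the change directly. Going by the values given here, the only step among the measured compounds, an 8.3-fold higher number from compound 2 to compound 3 (0.92 log units; beyond the scatter), replaced the amine itself and cost potency, which shows that this end of the molecule matters for the number. Removing the ring that positions the amine is a change of a different kind, and its effect can only be guessed. A modest loss is expected, somewhat beyond the scatter, with considerable uncertainty in both directions.

Compound 4 is therefore expected to give about 100 nM in this assay, between 30 nM and 400 nM, which would mean a step of a 3.3-fold higher number from compound 2 to compound 4 (0.52 log units; beyond the scatter).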

Compound 4, half-maximal inhibitory concentration: 330 nM
Compound 4: middle estimate off by 3.3-fold (0.52 log units), on the low side; the range from low to high includes it.
By their numbers in this assay, from the lowest: compound 2; then compound 1; then compounds 3 and 4 (each within the scatter of the next).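

In this assay the exchange of the ring-bearing group for the open chain gives an 11-fold higher number from compound 2 to compound 4 (1.04 log units; beyond the scatter), so keeping the primary amine is not enough to hold the number. The earlier step at this position, an 8.3-fold higher number from compound 2 to compound 3 (0.92 log units; beyond the scatter), altered only the amine end, whereas this one leaves the amine in place and shows that the part joining it to the five-membered aromatic ring also matters. No measurement at hand bears on why 4-aminobutyl gives a higher number than 4-(aminomethyl)phenyl.

A single chain cannot show whether any flexible linker would behave this way, or whether 4-aminobutyl is simply the wrong length, and a shorter or longer chain ending in the same amine would test that. On these data alone, it also remains open whether the aromatic ring itself is needed or any ring would serve, a question that a saturated cyclohexane ring carrying the same aminomethyl group could help to answer.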